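This account rests on a few compounds, and the source may have more. Where it says the series, first, only, none or still open, it means among the compounds named here.

Among the compounds with values here, in a functional assay on SiHa cells (Homo sapiens) for inhibition, read by CCK-8 assay, with a stated time of 72 h, tested at 1 uM (on this read-out higher numbers stand for more inhibition of growth at the one concentration tested and lower numbers for less inhibition of growth), compound 1 (`CN(C)C(=O)c1cc2cnc(Nc3ccc(NC(=O)C4(C(=O)Nc5ccccc5F)CC4)cc3)nc2n1C1CCCC1`) gives 63.4% and stands highest of the two numbers so far. Compound 2 (`CN(C)C(=O)c1cc2cnc(Nc3ccc(NC(=O)C4(C(=O)Nc5ccc(F)cc5)CC4)cc3F)nc2n1C1CCCC1`) gives 6.6% in the same read-out. The gap between these two numbers lies beyond the scatter. Compound 3 (`CN(C)C(=O)c1cc2cnc(Nc3ccc(NC(=O)C4(C(=O)Nc5ccc(O)cc5)CC4)cc3)nc2n1C1CCCC1`) carries one change from compound 1 (4-hydroxyphenyl in place of 2-fluorophenyl on an amide-type nitrogen), 4-hydroxyphenyl in place of 2-fluorophenyl on an amide-type nitrogen. Within the data shown here, no measured step isolates this change, but compound 2, which also lacks the 2-fluorophenyl, gives 6.6% here. A fall beyond the scatter is expected (a number 28.4 percentage points lower from compound 1 to compound 3 (beyond the scatter)). Compound 3 is estimated at 35% with an expected range from 8% to 65% on measurement.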

Compound 3, percent growth inhibition at one concentration: 69.5%
Estimate against measurement, compound 3: 34.5 percentage points below; measured number outside the range, above it.
By their numbers in this assay, from the lowest: compound 2; then compounds 1 and 3 (each within the scatter of the next).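

On the amide-type nitrogen, in this assay, 4-hydroxyphenyl in place of 2-fluorophenyl gives a number 6.1 percentage points higher from compound 1 to compound 3 (within the scatter), so the 2-fluorophenyl is not needed to keep inhibition of growth at this position. The entering group brings one hydrogen-bond donor and one hydrogen-bond acceptor that the 2-fluorophenyl lacks, and the read-out holds. Nothing available explains why the two groups read alike.

Still open, on these data alone, is whether a 4-aminophenyl, a 4-carboxyphenyl or an unsubstituted phenyl on the same nitrogen reads likewise. One concentration also leaves open whether compound 1 and compound 3 would stay level at other concentrations.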